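The compounds below may be only part of what the source reports. "The series", "measured", "known", "first", "only" and "open" are said of these compounds alone.

Within the data shown here, compound 2 `CC(C(=O)NCc1ccc(C(F)(F)F)nc1N1CCC(=O)CC1)c1ccc(NS(C)(=O)=O)c(F)c1` gives 91 nM in a functional assay on CHO-K1 cells for antagonist activity at transient receptor potential cation channel subfamily V member 1 (Homo sapiens), read by FLIPR (a higher number here means a weaker inhibitor, a lower number a stronger inhibitor), the higher of the two numbers measured so far. Among the measured compounds shown here, compound 1 `CC(C(=O)NCc1ccc(C(F)(F)F)nc1NCc1ccccc1)c1ccc(NS(C)(=O)=O)c(F)c1` gives 15.8 nM, and the one measured step, a 5.8-fold higher number from compound 1 to compound 2 (0.76 log units; beyond the scatter), exchanges the whole group on that aromatic carbon. Compound 3 `CC(=O)OC1CCN(c2nc(C(F)(F)F)ccc2CNC(=O)C(C)c2ccc(NS(C)(=O)=O)c(F)c2)CC1` differs from compound 2 by 4-acetoxypiperidin-1-yl in place of 4-oxopiperidin-1-yl on an aromatic carbon, keeping the six-membered non-aromatic ring and changing only what sits on it. For the measured compounds named here, no measured step bears directly on this smaller change, so compound 3 is expected to show a 1.3-fold lower number from compound 2 to compound 3 (0.11 log units; within the scatter) in this assay, a step that may stay within the scatter. The estimate for compound 3 is 70 nM, ranging from 25 nM to 200 nM.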

Compound 3, inhibition constant: 4 nM
Compound 3: the middle estimate sits 18-fold (1.24 log units) above what was measured; measured number below the stated range.
By their numbers in this assay, from the lowest: compound 3; then compound 1; then compound 2.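

At this position, next to the ring nitrogen, the six-membered ring can carry very different activity depending on what sits on it: replacing the ketone of 4-oxopiperidin-1-yl with 4-acetoxypiperidin-1-yl gives a large change (a 23-fold lower number from compound 2 to compound 3 (1.36 log units; beyond the scatter)). The non-aromatic ring is therefore not in itself a drawback, as compound 2 alone might have suggested, since the acetoxy ring also improves on benzylamino (a 4.0-fold lower number from compound 1 to compound 3 (0.60 log units; beyond the scatter)). No measurement available here explains this gain.

Going by these compounds, it remains open whether the acetyl part is needed, which a 4-hydroxypiperidin-1-yl group would test. Also open, on these data alone, is whether a 4-aminopiperidin-1-yl group or a longer ester chain would hold the gain.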